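Carrying a Fluoro Substitution Across to a Sibling Core

A few compounds are considered here, and "the series" means these few. Any claim that something is new, unique, unknown or untested is made for them only; others in the source may bear on it.

Of the compounds shown here, three have been tested in a functional assay on PC-3 cells (Homo sapiens) for cytotoxicity, read by WST assay, with a stated time of 48 h; on this read-out lower numbers stand for stronger inhibition and higher numbers for weaker inhibition. Compound 3 `COc1ccc2c(/C=C(\C#N)C(=O)c3c[nH]c4ccccc34)c[nH]c2c1` gives 12500 nM. Compound 1 `COc1ccc2c(/C=C(\C#N)C(=O)c3c[nH]c4cc(F)ccc34)c[nH]c2c1` keeps the same core and differs in a single place: fluoro in place of hydrogen on an aromatic carbon. In this assay compound 1 gives 21400 nM, and the step of a 1.7-fold higher number from compound 3 to compound 1 (0.23 log units; within the scatter). Compound 2 `COc1ccc2[nH]cc(/C=C(\C#N)C(=O)c3c[nH]c4ccccc34)c2c1` is built from the same atoms as compound 3, joined in a different way; how the two cores differ is not broken down here. In this assay compound 2 gives 30500 nM, a higher number than compound 3, while its value sits alongside that of compound 1 within the usual scatter.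

Compound 4 `COc1ccc2[nH]cc(/C=C(\C#N)C(=O)c3c[nH]c4cc(F)ccc34)c2c1` has not yet been measured. It stands to compound 2 as compound 1 stands to compound 3: fluoro in place of hydrogen on an aromatic carbon. The place of the entering fluorine is described in the same words in both cases, so this is the same change, now made on a core whose difference from that of compound 3 is not broken down. Because the measured step of a 1.7-fold higher number from compound 3 to compound 1 (0.23 log units; within the scatter) was small, the expected step of a 1.5-fold higher number from compound 2 to compound 4 (0.17 log units; within the scatter) is also small, and it rests on a single earlier example of the change. On that basis compound 4 is expected to give about 45000 nM in this assay, with a likely range from 20000 nM to 100000 nM.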

Compound 4, half-maximal inhibitory concentration: > 50000 nM
Compound 4 gave a limit, no number; the forecaster's own chance of this, stated with the estimate: 15%; middle value at least 1.1-fold (0.04 log units) from the limit.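

In this assay compound 4 gives > 50000 nM, which is a limit of the assay and not a number. The new step can therefore be read only as a floor, an at least 1.6-fold higher number from compound 2 to compound 4 (0.21 log units; that floor lies within the scatter), and set beside the step on the other core it gives this picture: the same change on two cores in this assay, a 1.7-fold higher number (0.23 log units; within the scatter) from compound 3 to compound 1 and an at least 1.6-fold higher number (0.21 log units; that floor lies within the scatter) from compound 2 to compound 4; the limit leaves it open whether they differ The result is compatible with the change carrying over from one core to the other unaltered, but it does not show that it does, as a far larger step on the core of compound 2 would fit the limit just as well.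

The compounds shown have only hydrogen or fluoro at this place, so it stays open what a chloro group, an amine or a carboxylic acid there would do on either core. Also open, from the compounds shown here alone, is whether fluoro on another aromatic carbon of the same ring would give a similar result on the two cores.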